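The compounds below may be only part of what the source reports. "The series", "measured", "known", "first", "only" and "open" are said of these compounds alone.

Measured so far:
compound 1 `O=C(/C=C/c1ccc(OCc2cn(Cc3ccccc3F)nn2)cc1)c1ccc(Br)cc1` gives 28% in a functional assay on MIA PaCa-2 cells (Homo sapiens) for inhibition, read by MTT assay, with a stated time of 48 h, tested at 10 uM; on this read-out higher numbers stand for more inhibition of growth at the one concentration tested and lower numbers for less inhibition of growth
compound 2 `O=C(/C=C/c1ccc(OCc2cn(Cc3ccc(F)cc3)nn2)cc1)c1ccc(Br)cc1` gives 32% in this assay

Among the compounds with values here, compound 2 holds the higher of the two numbers, but its only neighbour is compound 1 and the gap, a number 4 percentage points higher from compound 1 to compound 2 (within the scatter), lies within the scatter, so the two stand level on this read-out. Compound 3 `COc1ccc(C(=O)/C=C/c2ccc(OCc3cn(Cc4ccc(F)cc4)nn3)cc2)cc1` keeps the whole framework of compound 2 and changes only the aryl on the carbonyl side: methoxy in place of bromo on an aromatic carbon. Within the data shown here, the single measured step concerns the fluorine on the benzyl group at the other end of the molecule and says nothing about the carbonyl-side aryl; no measured pair varies that ring. With nothing bearing on the change, the expectation for this assay is a step no larger than the scatter, no change at the digits printed from compound 2 to compound 3 (within the scatter), in either direction. Compound 3 is therefore estimated at 32%, within a range from 14% to 50%.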

Compound 3, percent growth inhibition at one concentration: 6%
For compound 3 the middle estimate is 26 percentage points above the measured one; measured number outside the range, below it.
By their numbers in this assay, from the lowest: compound 3; then compounds 1 and 2 (each within the scatter of the next).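

In this assay, within the data shown here, the change from 4-bromophenyl to 4-methoxyphenyl on the carbonyl gives a number 26 percentage points lower from compound 2 to compound 3 (beyond the scatter) and shows that this ring position, which no earlier pair varied, does respond to its substituent. Among these compounds, the only earlier step, a number 4 percentage points higher from compound 1 to compound 2 (within the scatter) for the fluorine on the other end of the molecule, stays within the scatter, so this is the first single change to move the number beyond it. Nothing available explains this drop.

From the compounds shown here alone, with one pair at this position, it remains open whether the outcome follows from gaining methoxy or losing bromo, and a chloro, hydroxy or dimethylamino group in the same place would help separate the two. Going by these compounds, it is also open whether the same change would give a similar step with the 2-fluorophenyl group of compound 1 in place.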